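A few compounds are considered here, and "the series" means these few. Any claim that something is new, unique, unknown or untested is made for them only; others in the source may bear on it.

Three compounds from this series share one core and differ only in the substituent on that shared core. Compound 1 carries a phenylsulfanyl group `CC1=CCC[C@H]2[C@](C)(CC3=CC(=O)C=C(Sc4ccccc4)C3=O)[C@@H](C)CC[C@]12C`; compound 2 carries a methoxy group `COC1=CC(=O)C=C(C[C@]2(C)[C@@H](C)CC[C@]3(C)C(C)=CCC[C@@H]23)C1=O`; compound 3 carries an isopropylsulfanyl group `CC1=CCC[C@H]2[C@](C)(CC3=CC(=O)C(SC(C)C)=CC3=O)[C@@H](C)CC[C@]12C`. In an ADME assay on PBMC cells (Homo sapiens) for inhibition, read by MTT assay (a higher number here means a weaker inhibitor, a lower number a stronger inhibitor), compound 2 gives 5500 nM. For compound 3 the entry in this assay is "not determined" (no result reported), and for compound 1 the entry is "not determined" (no result reported), so compound 3 stands without a measured anchor of its own, and the only numerical reference in the set is that of compound 2.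

Compound 4 `CC1=CCC[C@H]2[C@](C)(CC3=CC(=O)C(SC(C)(C)C)=CC3=O)[C@@H](C)CC[C@]12C` differs from compound 3 by one change: methyl in place of hydrogen on a saturated chain carbon bound to two saturated chain carbons and a sulfur. Going by the values given here, no measured pair in this set shows the effect of such a change, so the step from compound 3 to compound 4 in this assay cannot be drawn from data; with nothing to point either way, a step no larger than the usual scatter, in either direction, is the working assumption. Taking the value of compound 2 as the only available guide, compound 4 is expected to give about 5000 nM in this assay, with a plausible range from 1500 nM to 16000 nM.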

Compound 4, half-maximal inhibitory concentration: 20800 nM
The estimate for compound 4 lay 4.2-fold (0.62 log units) below the measured number; the whole stated range lies below it.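

Going by these compounds alone, no step from compound 3 to compound 4 can be read from this result in this assay. The compounds shown leave open how the change from isopropylsulfanyl to (tert-butyl)sulfanyl on the shared core shifts inhibition in this assay. No available evidence bears on the result for compound 4.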